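The compounds below may be only part of what the source reports. "The series", "measured", "known", "first", "only" and "open" are said of these compounds alone.

Measured in an ADME assay on Akata cells (Homo sapiens) for cytotoxicity, with a stated time of 7 days; a higher number here means that more compound is tolerated, a lower number that less compound is tolerated:
Compound 1 `CNc1nc(N)nc2c1ncn2/C=C1/CC1(CO)CO`: > 24000 nM
Compound 2 `CC(C)Nc1nc(N)nc2c1ncn2/C=C1/CC1(CO)CO`: > 24000 nM

Compound 2 gives > 24000 nM in this assay, and this is a limit of the assay, not a number. Among the compounds with values here, compound 1 also gives a limit, so the series so far consists of the limit of > 24000 nM in this assay, at which 2 of the 2 values shown sit. Neither compound therefore has a readable value, and compound 2 can be placed only at that limit.

Compound 3 `Nc1nc(NC2CCCC2)c2ncn(/C=C3/CC3(CO)CO)c2n1` is the next member, and its change from compound 2 is cyclopentyl in place of isopropyl on a nitrogen on an aromatic ring. In words, cyclopentyl stands in place of isopropyl on a nitrogen on an aromatic ring.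

Within the data shown here, only one measured step bears on this change, and it concerns the same nitrogen: a step that the two limits leave unreadable from compound 1 to compound 2. Among the measured compounds shown here, it offers no size to carry forward, and no measured step shows what a ring does at this place. For the measured compounds named here, the expectation is thus only that no change beyond the scatter appears in this assay, with a real chance of another limit. The expected change is a number no higher from compound 2 to compound 3 (the limit leaves the size open). For compound 3 the estimate is 24000 nM, with an expected range of 8000 nM to 50000 nM.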

Compound 3, half-maximal cytotoxic concentration: > 20000 nM
Compound 3: a limit, no number; the forecaster's own chance of this, stated with the estimate: 65%; the middle value is on the limit's open side.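

In this assay compound 3 gives > 20000 nM, which is a limit of the assay and not a number. Within the data shown here, compound 1, compound 2 and compound 3 all stand at limits, so no step among them can be read. The compounds shown leave open whether the group on the nitrogen changes the tolerated concentration at all.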